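Phenyl halogen variation: outlook for compound 3

The compounds below may be only part of what the source reports. "The series", "measured", "known", "first", "only" and "open" are said of these compounds alone.

Compound 1 `CCOC(=O)c1c(C)[nH]c(=O)c(C#N)c1-c1ccccc1` gives 22000 nM in a functional assay on MCF7 cells (Homo sapiens) for inhibition, read by MTT assay, with a stated time of 24 h; on this read-out higher numbers stand for weaker inhibition and lower numbers for stronger inhibition. Compound 2 `CCOC(=O)c1c(C)[nH]c(=O)c(C#N)c1-c1ccc(Br)cc1` gives 31800 nM in this assay and occupies the higher of the two numbers, a gap that a 1.4-fold higher number from compound 1 to compound 2 (0.16 log units; within the scatter) shows lies inside the scatter. Compound 3 `CCOC(=O)c1c(C)[nH]c(=O)c(C#N)c1-c1ccccc1Cl` differs from compound 2 by 2-chlorophenyl in place of 4-bromophenyl on an aromatic carbon. For the measured compounds named here, the only step bearing on this change is a 1.4-fold higher number from compound 1 to compound 2 (0.16 log units; within the scatter), where adding a halogen to the same phenyl did not move the number beyond the scatter. Nothing separates the 2-chlorophenyl from the 4-bromophenyl here, so compound 3 is expected to show a 1.1-fold lower number from compound 2 to compound 3 (0.06 log units; within the scatter). Compound 3 is estimated at 28000 nM, within 12000 nM to 70000 nM.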

Compound 3, half-maximal inhibitory concentration: 25400 nM
The estimate for compound 3 lay 1.1-fold (0.04 log units) above the measured number; the measured number falls inside the stated range.
By their numbers in this assay, from the lowest: compounds 1, 3 and 2 (each within the scatter of the next).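

In this assay, 2-chlorophenyl in place of 4-bromophenyl gives a 1.3-fold lower number from compound 2 to compound 3 (0.10 log units; within the scatter), and chloro in place of hydrogen gives a 1.2-fold higher number from compound 1 to compound 3 (0.06 log units; within the scatter). A halogen on this phenyl has therefore stayed within the scatter of the unsubstituted phenyl in both examples, with bromo and chloro at two different places on the ring. No measurement at hand bears on the reason for these small steps. Still open, as far as these compounds go, is whether an amine or a methoxy group on this phenyl, or a carboxylic acid in place of the ethoxycarbonyl group, would move the number beyond the scatter.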